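This account rests on a few compounds, and the source may have more. Where it says the series, first, only, none or still open, it means among the compounds named here.

In a functional assay on K562 cells (Homo sapiens) for inhibition (a higher number here means a weaker inhibitor, a lower number a stronger inhibitor), compound 1 (`CCOc1ccc(Br)cc1-c1cc(Nc2ccc(C#N)cc2)nc(N)n1`) gives 70 nM and compound 2 (`CCOc1ccc(Br)cc1-c1cc(Nc2cccc(C#N)c2)nc(N)n1`) gives 350 nM in the same test. Trading 4-cyanophenyl for 3-cyanophenyl thus makes a 5.0-fold higher number from compound 1 to compound 2 (0.70 log units; beyond the scatter) and this modest step lies beyond the scatter. Compound 3 (`CCOc1ccc(Br)cc1-c1cc(Nc2ccc(/C(C)=N\O)cc2)nc(N)n1`) reads < 50 nM and this is a limit of the assay, not a number. The comparison gives an at least 1.4-fold lower number from compound 1 to compound 3 (0.14 log units; that floor lies within the scatter) and that floor lies within the scatter, so compound 3 has no exact place yet.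

The change to compound 4 (`CCOc1ccc(Br)cc1-c1cc(Nc2ccc(Cl)cc2)nc(N)n1`), not yet measured, is one chlorine atom in place of a group of 4 heavy atoms (2 carbon, 1 nitrogen, 1 oxygen; no ring), on an aromatic carbon on an aromatic carbon, para to a large group. Among the compounds with values here, no measured step brings in chloro, so the guidance is indirect. Compound 1 carries a small group in that same place and gives 70 nM as the nearest reference. A modest step towards a higher number is therefore expected, though it may stay within the scatter. The expected change is an at least 2.0-fold higher number from compound 3 to compound 4 (0.30 log units; that floor lies within the scatter) in this assay on this reasoning. For compound 4 the estimated value is 100 nM with an expected range from 35 nM to 300 nM in this test.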

Compound 4, half-maximal inhibitory concentration: 50 nM
The estimate for compound 4 lay 2.0-fold (0.30 log units) above the measured number; measured number inside the range.
By their numbers in this assay, from the lowest: compounds 4 and 1 (each within the scatter of the next); then compound 2.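

In this assay, chloro in place of the nitrile on this aromatic carbon, para to a large group, gives a 1.4-fold lower number from compound 1 to compound 4 (0.15 log units; within the scatter), so the nitrile is not needed for a value in this range and the two compounds cannot be told apart. Compound 4, with its 4-chlorophenyl group, also stands clear of the 3-cyanophenyl compound, with a 7.0-fold lower number from compound 2 to compound 4 (0.85 log units; beyond the scatter). One chlorine atom in place of the group of 4 heavy atoms gives a number no lower from compound 3 to compound 4 (the limit leaves the size open). The size of that step cannot be read, because compound 3 stands at a limit of the assay and not at a number: the limit of < 50 nM in this assay, at which 1 of the 4 values shown sits.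

From the compounds shown here alone, how an amine, a carboxylic acid or a methoxy group would read at this same place remains open. Going by these compounds, the exact standing of compound 3 against compound 1 and compound 4 also remains open.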